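Amine substituent series: furanylmethyl to acetamidobenzyl

This account rests on a few compounds, and the source may have more. Where it says the series, first, only, none or still open, it means among the compounds named here.

Compound 2 `c1cc(CNC2CCN(CCCc3c[nH]c4ccc(-n5cnnc5)cc34)CC2)co1` gives the lower of the two numbers recorded so far in a functional assay on CHO cells for activation of 5-hydroxytryptamine receptor 1D (Homo sapiens), read by GTPgammaS binding (a lower number here means a smaller maximal response, a higher number a larger maximal response), at 65%. Compound 1 `COC[C@H](NC1CCN(CCCc2c[nH]c3ccc(-n4cnnc4)cc23)CC1)c1ccccc1` reaches 93%, and the step of a number 28 percentage points lower from compound 1 to compound 2 (beyond the scatter) shows that changing the substituent on this amine nitrogen shifts the maximal response. Compound 3 `CC(=O)Nc1ccc(CNC2CCN(CCCc3c[nH]c4ccc(-n5cnnc5)cc34)CC2)cc1` carries 4-acetamidophenyl in place of furan-3-yl on a saturated chain carbon bound to an amine nitrogen. Among the measured compounds shown here, only the one step above touches the same position, and it was modest; a return toward a six-membered aromatic group is expected to raise the response modestly, a number 10 percentage points higher from compound 2 to compound 3 (within the scatter). Compound 3 is thus estimated at 75%, within 55% to 95%.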

Compound 3, largest response reached (reported as efficacy), in percent of the reference or control that the assay uses: 75%
For compound 3 middle estimate and measured number coincide at the digits printed; the range from low to high includes it.
By their numbers in this assay, from the lowest: compounds 2 and 3 (each within the scatter of the next); then compound 1.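

In this assay, 4-acetamidophenyl in place of furan-3-yl gives a number 10 percentage points higher from compound 2 to compound 3 (within the scatter), so this exchange of ring and added acetamido group does not separate the two compounds. Against 2-methoxy-1-phenylethyl, the 4-acetamidobenzyl group still gives a number 18 percentage points lower from compound 1 to compound 3 (beyond the scatter), so a six-membered aromatic ring alone does not close that gap. No measured data bear on the origin of either step. Open, on these data alone, is whether plain benzyl matches 4-acetamidobenzyl, and whether 1-phenylethyl, lacking the methoxy group, keeps the response of compound 1.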